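This account rests on a few compounds, and the source may have more. Where it says the series, first, only, none or still open, it means among the compounds named here.

The set rests on two closely related cores. Compound 2 `Cc1nc(N)c2c(I)cn([C@@H]3O[C@H](CO)[C@@H](O)[C@H]3O)c2n1` carries iodo on its core, and compound 1 `Cc1nc(N)c2c(-c3ccccc3)cn([C@@H]3O[C@H](CO)[C@@H](O)[C@H]3O)c2n1` carries phenyl in its place; compound 3 `CNc1ncnc2c1c(I)cn2[C@@H]1O[C@H](CO)[C@@H](O)[C@H]1O` pairs the iodo with the other core, and compound 4 `CNc1ncnc2c1c(-c1ccccc1)cn2[C@@H]1O[C@H](CO)[C@@H](O)[C@H]1O` is its phenyl counterpart, not yet measured. The difference between the two cores is not broken down here. In a functional assay on A549 cells (Homo sapiens), read by MTT assay, with a stated time of 72 h (on this read-out lower numbers stand for stronger inhibition and higher numbers for weaker inhibition), compound 2 gives 12100 nM. Compound 1 reaches only a limit of this assay, > 20000 nM. The change phenyl in place of iodo on an aromatic carbon thus gave an at least 1.6-fold higher number from compound 2 to compound 1 (0.21 log units; that floor lies within the scatter). Compound 3 also sits at a limit of this assay, > 100000 nM. The same change is now made from compound 3 to compound 4, (phenyl in place of iodo on an aromatic carbon), at a place described in the same words. Since compound 3 already stands at the limit of > 100000 nM in this assay, at which 1 of the 3 values shown sits, and the earlier step of an at least 1.6-fold higher number from compound 2 to compound 1 (0.21 log units; that floor lies within the scatter) did not lower the number, compound 4 is expected to move by about a step that the limit leaves unreadable from compound 3 to compound 4. Compound 4 is therefore estimated at 150000 nM in this assay, expected between 50000 nM and 500000 nM, and most likely reported only as a limit.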

Compound 4, half-maximal inhibitory concentration: > 20000 nM
Compound 4 ended at the assay's limit (the forecaster's own chance of this, stated with the estimate: 85%); the middle value is on the limit's open side.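

Compound 3 and compound 4 both stand only at limits of this assay, so the size of the step between them cannot be read. The compounds shown leave open how far phenyl in place of iodo on an aromatic carbon moves the number on the core of compound 3, if it moves it at all.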